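This account rests on a few compounds, and the source may have more. Where it says the series, first, only, none or still open, it means among the compounds named here.

Measured compounds:
compound 1 `COc1cccc(C(c2c[nH]c3ccc(Br)cc23)c2c[nH]c3ccc(Br)cc23)c1OC`: in a functional assay on A549 cells (Homo sapiens) for inhibition, read by MTT assay, with a stated time of 48 h (a lower number here means a stronger inhibitor, a higher number a weaker inhibitor), compound 1 gives 100000 nM
compound 2 `COc1ccc(C(c2c[nH]c3ccc(Br)cc23)c2c[nH]c3ccc(Br)cc23)c(OC)c1`: in this assay compound 2 gives 100000 nM

Within the data shown here, compound 1 stands level with compound 2 in this assay, the only measured step being no change at the digits printed from compound 1 to compound 2 (within the scatter). The unmeasured compound 3 `CCCCCCCC(c1c[nH]c2ccc(Br)cc12)c1c[nH]c2ccc(Br)cc12` differs from compound 1 as follows: heptyl in place of 2,3-dimethoxyphenyl on a saturated chain carbon bound to two aromatic carbons. Among the measured compounds shown here, the one measured step exchanges one dimethoxyphenyl for another on the same saturated chain carbon and moves nothing, whereas here an aromatic group leaves and a heptyl chain enters; no measured step exchanges an aromatic group for a chain, so nothing measured bears directly on this change. With both measured compounds at the same weak value, compound 3 is expected to stay near that value, and the step of a 1.3-fold lower number from compound 1 to compound 3 (0.10 log units; within the scatter) is estimated to be small. The estimate for compound 3 in this assay is 80000 nM, with a range from 15000 nM to 100000 nM.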

Compound 3, half-maximal inhibitory concentration: 3500 nM
Estimate against measurement, compound 3: 23-fold (1.36 log units) above; measured number below the stated range.
By their numbers in this assay, from the lowest: compound 3; then compounds 1 and 2 (each within the scatter of the next).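

In this assay the saturated chain carbon bound to two aromatic carbons turns out to be a place where the read-out can move: heptyl in place of 2,3-dimethoxyphenyl gives a 29-fold lower number from compound 1 to compound 3 (1.46 log units; beyond the scatter) and heptyl in place of 2,4-dimethoxyphenyl gives a 29-fold lower number from compound 2 to compound 3 (1.46 log units; beyond the scatter) in the same shared core. Among these compounds, the earlier exchange of one dimethoxyphenyl for another gave no change at the digits printed from compound 1 to compound 2 (within the scatter) and so showed only that these two aromatic groups sit level, not that the position is insensitive. No measurement on hand accounts for this large step.

As far as these compounds go, whether the step belongs to the loss of the aromatic ring or to the entry of the chain stays open, and cyclohexyl at this place would separate the two. Also open, from the compounds shown here alone, is how the value follows chain length and chain end, with a shorter chain such as butyl, a longer chain such as decyl, or a heptyl chain ending in an amine or a carboxylic acid.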